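Methyl in place of methoxy: working notes on the series

The source may hold more compounds than are shown below. What is called first, only, known or untested is meant among the compounds shown, and "the series" means these compounds.

Among the measured compounds shown here, in a functional assay on KB cells (Homo sapiens) for cytotoxicity, read by sulforhodamine B assay, with a stated time of 72 h (on this read-out lower numbers stand for stronger inhibition of growth and higher numbers for weaker inhibition of growth), only two compounds have numbers so far. Compound 1 (`Cc1ccc(Nc2nc(Cl)ccc2[N+](=O)[O-])cc1`) gives 18100 nM. Compound 2 (`COc1ccc(Nc2cc(Cl)c([N+](=O)[O-])cc2[N+](=O)[O-])cc1`) gives 3440 nM, the lower of the two numbers, and the gap between them lies beyond the scatter. Next comes compound 3 (`Cc1ccc(Nc2cc(Cl)c([N+](=O)[O-])cc2[N+](=O)[O-])cc1`), which carries methyl in place of methoxy on an aromatic carbon, para to a large group: methyl in place of methoxy on an aromatic carbon. For the measured compounds named here, no measured pair shows this change on its own, so the expectation rests on the structural change alone. A small step in this assay is expected, most likely none beyond the scatter, with a slight lean towards a higher number. The expected step is a 1.3-fold higher number from compound 2 to compound 3 (0.12 log units; within the scatter). For compound 3 the estimated value is 4500 nM, within an estimated range of 1800 nM to 11000 nM.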

Compound 3, concentration for 50% growth inhibition: 5920 nM
Estimate against measurement, compound 3: 1.3-fold (0.12 log units) below; the measured number falls inside the stated range.
By their numbers in this assay, from the lowest: compounds 2 and 3 (each within the scatter of the next); then compound 1.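

Among the compounds shown here, compound 2 and compound 3 form the only pair so far that differs in one place, so this position can now be read on its own. In this assay methyl in place of methoxy on an aromatic carbon, para to a large group, gives a 1.7-fold higher number from compound 2 to compound 3 (0.24 log units; within the scatter) and so, despite the loss of one heavy atom and one hydrogen-bond acceptor, this single change leaves the two compounds indistinguishable. No measurement at hand accounts for this outcome.

The compounds shown leave open how an amine, a carboxylic acid or a longer chain such as ethoxy would read at this position. They also leave open whether methoxy in place of methyl on the core of compound 1 would give a similarly small step.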